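This account rests on a few compounds, and the source may have more. Where it says the series, first, only, none or still open, it means among the compounds named here.

Values so far in a functional assay on HCT-116 cells (Homo sapiens) for antiproliferative activity, read by CCK-8 assay, with a stated time of 72 h; a higher number here means a weaker inhibitor, a lower number a stronger inhibitor:
compound 1 `Nc1ccccc1NC(=O)c1ccc(CSC(=S)N2CCc3ccccc32)cc1` gives 2700 nM
compound 2 `Nc1ccccc1NC(=O)c1ccc(CSC(=S)N2CCc3cc(Cl)ccc32)cc1` gives 3210 nM

Compound 2 at 3210 nM sits level with compound 1 within the scatter, so neither stands apart on these two numbers. The next entry is compound 3 `COC(=O)c1ccc2c(c1)CCN2C(=S)SCc1ccc(C(=O)Nc2ccccc2N)cc1`, which carries methoxycarbonyl in place of chloro on an aromatic carbon. Its difference from compound 2 counts as methoxycarbonyl in place of chloro on an aromatic carbon for this exchange. Among the measured compounds shown here, the only measured step that bears on it is a 1.2-fold higher number from compound 1 to compound 2 (0.08 log units; within the scatter) for chloro in place of hydrogen on an aromatic carbon, and that step lies within the scatter. For the measured compounds named here, it is a single step, and no measured compound carries methoxycarbonyl, so the guidance is thin. On the strength of a 1.2-fold higher number from compound 1 to compound 2 (0.08 log units; within the scatter) alone, no step beyond the scatter is expected in this assay and no direction is favoured. The estimated 1.0-fold higher number from compound 2 to compound 3 (0.01 log units; within the scatter) is expected to stay within the scatter. Compound 3 is estimated at 3300 nM with an expected range from 1400 nM to 8000 nM in this read-out.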

Compound 3, half-maximal inhibitory concentration: 13200 nM
Compound 3: middle estimate off by 4.0-fold (0.60 log units), on the low side; the measured number lies above the stated range.
By their numbers in this assay, from the lowest: compounds 1 and 2 (each within the scatter of the next); then compound 3.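

In this assay the position on the aromatic carbon, meta to a fused ring and para to a fused ring, now shows that its substituent can matter: the exchange of chloro for methoxycarbonyl gives a 4.1-fold higher number from compound 2 to compound 3 (0.61 log units; beyond the scatter) and the exchange of hydrogen for methoxycarbonyl gives a 4.9-fold higher number from compound 1 to compound 3 (0.69 log units; beyond the scatter) in the same direction, towards a weaker inhibitor. The earlier change of hydrogen to chloro, at a 1.2-fold higher number from compound 1 to compound 2 (0.08 log units; within the scatter), gave no sign of this, so the position is not indifferent to every group, and methoxycarbonyl is the only one of the three substituents shown that stands apart from the others. Nothing available here accounts for the loss seen with methoxycarbonyl.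

From the compounds shown here alone, with only three substituents at one position, it remains open whether the step belongs to the ester as a whole or to some part of it, which a carboxylic acid, a primary amide or a methoxy group at the same carbon would help to separate. Also open, going by these compounds, is whether a methyl group or a fluorine there would stay level with hydrogen and chloro, and whether the same exchange elsewhere on the ring would give a similar step.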